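A Bulkier Ester on the Methylated Core

The compounds below may be only part of what the source reports. "The series", "measured", "known", "first", "only" and "open" are said of these compounds alone.

Compound 3 `COC(=O)C1=C(C)N(C)C(=O)NC1c1ccoc1` carries a methyl on an amide-type nitrogen in a ring together with a methoxycarbonyl group. In an assay on membranes from CHO cells for displacement of a labelled ligand from adenosine receptor A1 (Homo sapiens), read by scintillation counting, with a stated time of 60 min, tested at 1 uM (on this read-out higher numbers stand for more inhibition at the one concentration tested (going by the name of the read-out) and lower numbers for less inhibition), compound 3 gives 15%. Compound 1 `COC(=O)C1=C(C)NC(=O)NC1c1ccoc1` gives 8% in this assay, and compound 2 `CC1=C(C(=O)OC(C)(C)C)C(c2ccoc2)NC(=O)N1` gives 11%. The three numbers sit within the scatter of one another, so none of them can be told apart from the rest on this read-out.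

Compound 4 `CC1=C(C(=O)OC(C)(C)C)C(c2ccoc2)NC(=O)N1C` has not yet been measured. It differs from compound 3 by tert-butyl in place of methyl on an oxygen next to a carbonyl group. Among the compounds with values here, one measured step bears on this change directly: the same exchange made on compound 1 gave a number 3 percentage points higher from compound 1 to compound 2 (within the scatter). The methyl on the ring nitrogen, the other feature that compound 3 carries, gave a number 7 percentage points higher from compound 1 to compound 3 (within the scatter) when introduced into compound 1. Both steps stayed inside the scatter, so nothing in these numbers suggests that enlarging the ester group moves the read-out in this assay beyond the scatter. For compound 4 the expected step is a number 2 percentage points higher from compound 3 to compound 4 (within the scatter). Compound 4 is therefore estimated at 17% in this assay, with a range from 5% to 30%.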

Compound 4, a percentage reported as inhibition, at one concentration (the size of the read-out at that concentration, not a potency): 21%
The estimate for compound 4 lay 4 percentage points below the measured number; the measured number falls inside the stated range.
By their numbers in this assay, from the lowest: compounds 1, 2, 3 and 4 (each within the scatter of the next, the first and the last beyond it).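

The change from methyl to tert-butyl on an oxygen next to a carbonyl group can now be read on a second core, where it gives a number 6 percentage points higher from compound 3 to compound 4 (within the scatter), and the two readings agree in this assay: the same change on two cores in this assay, a number 3 percentage points higher (within the scatter) from compound 1 to compound 2 and a number 6 percentage points higher (within the scatter) from compound 3 to compound 4, 3 percentage points apart, within the scatter of two such steps

The methyl on the amide-type nitrogen in a ring can likewise be read a second time, now with the tert-butyl ester in place, where it gives a number 10 percentage points higher from compound 2 to compound 4 (within the scatter), and again the two readings agree: the same change on two cores in this assay, a number 7 percentage points higher (within the scatter) from compound 1 to compound 3 and a number 10 percentage points higher (within the scatter) from compound 2 to compound 4, 3 percentage points apart, within the scatter of two such steps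

Each change thus stays within the scatter on both cores, and neither step differs measurably with the group present at the other place.

The compounds shown cover only methyl and tert-butyl on this oxygen and only hydrogen and methyl on the ring nitrogen, so it remains open whether a longer chain such as n-hexyl on the oxygen, a benzyl group there, or a free carboxylic acid in place of the ester would give a step beyond the scatter. All the numbers also come from a single tested concentration, so they give no potency for any of the four compounds.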